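The source may report more compounds than this note shows. Statements on the series, on what has been measured and on what is new or still open speak of the compounds shown alone.

Working notes on the series. In a functional assay on K562 cells (Homo sapiens) for antiproliferative activity, read by MTT assay, with a stated time of 24 h (a higher number here means a weaker inhibitor, a lower number a stronger inhibitor), compound 1 `COc1ccc(C(=O)/C=C/c2cc(OC)c(OC)c(OC)c2)c2c1C=CC(C)(C)O2` is reported only as a limit of the assay, > 10000 nM. Compound 2 `COc1ccc(C(=O)/C=C/c2ccco2)c2c1C=CC(C)(C)O2` is likewise reported only as a limit, > 10000 nM. Going by the values given here, both entries therefore sit at the limit of > 10000 nM in this assay, at which 2 of the 2 values shown sit, so compound 1 cannot be placed against compound 2 and no measured step exists anywhere in the set to anchor it.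

Compound 3 `COc1cc(/C=C/C(=O)c2ccc(OC)c3c2OC(C)(C)C=C3)cc(OC)c1O` differs from compound 1 by hydrogen in place of methyl on an oxygen on an aromatic ring. Among the compounds with values here, no measured pair shows this change, and because compound 1 sits at the limit of > 10000 nM in this assay, at which 2 of the 2 values shown sit, no direction can be read off. The step from compound 1 to compound 3 is expected to be a step that the limit leaves unreadable from compound 1 to compound 3, with no movement beyond the scatter anticipated. Compound 3 is accordingly estimated at 15000 nM, within 3000 nM to 60000 nM, and most likely to return only a limit again.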

Compound 3, half-maximal inhibitory concentration: > 10000 nM
Compound 3: only a limit was reported; the forecaster's own chance of this, stated with the estimate: 70%; the middle value lies beyond the limit too.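

The step from compound 1 to compound 3, methoxy to hydroxy, cannot be read in this assay, since both entries are limits: the limit of > 10000 nM in this assay, at which 3 of the 3 values shown sit.

The compounds shown leave open whether methoxy to hydroxy changes activity at all, and which structural change would give a readable value.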